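The source may hold more compounds than are shown below. What is called first, only, known or untested is meant among the compounds shown, and "the series" means these compounds.

Measured in an assay on microsomes for inhibition of acyl-CoA:cholesterol acyltransferase (Oryctolagus cuniculus); on this read-out lower numbers stand for stronger inhibition and higher numbers for weaker inhibition:
- compound 1, `Cc1cccc(C2(CNC(=O)Nc3c(C(C)C)cccc3C(C)C)CCCC2)c1`: 15 nM
- compound 2, `CC(C)c1cccc(C(C)C)c1NC(=O)NCC1(c2ccccc2C(F)(F)F)CCCC1`: 18 nM
- compound 3, `CC(C)c1cccc(C(C)C)c1NC(=O)NCC1(c2ccc(N)cc2)CCCC1`: 29 nM

Compound 1 has the lowest number of the three, but none of its steps to the others clears the scatter: a 1.2-fold higher number from compound 1 to compound 2 (0.08 log units; within the scatter) and a 1.9-fold higher number from compound 1 to compound 3 (0.29 log units; within the scatter). The pair of its neighbours is no different, with a 1.6-fold higher number from compound 2 to compound 3 (0.21 log units; within the scatter). Taken together, the three measured compounds show that exchanging the aryl group on the saturated ring carbon, whether for a trifluoromethyl-bearing ring or for an amino-bearing one, has left the read-out essentially where it was.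

Compound 4, `Cc1ccc(C2(CNC(=O)Nc3c(C(C)C)cccc3C(C)C)CCCC2)c(C)c1`, is the next variation at the same position; relative to compound 1 the change is 2,4-dimethylphenyl in place of 3-methylphenyl on a saturated ring carbon. Among the compounds with values here, the steps that bear on it are the two aryl exchanges from compound 1, both within the scatter, so a further methyl-substituted phenyl is not expected to move the number beyond the scatter either. The step from compound 1 to compound 4 is therefore expected to be a 1.2-fold higher number from compound 1 to compound 4 (0.08 log units; within the scatter). For compound 4 in this assay the estimate is 18 nM, with a range from 8 nM to 40 nM.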

Compound 4, half-maximal inhibitory concentration: 50 nM
Compound 4: the middle estimate sits 2.8-fold (0.44 log units) below what was measured; the measured number lies above the stated range.
By their numbers in this assay, from the lowest: compounds 1, 2, 3 and 4 (each within the scatter of the next, the first and the last beyond it).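

Working notes: in this assay this aryl position on a saturated ring carbon now gives steps beyond the scatter, both modest, with a 3.3-fold higher number from compound 1 to compound 4 (0.52 log units; beyond the scatter) and a 2.8-fold higher number from compound 2 to compound 4 (0.44 log units; beyond the scatter) once 2,4-dimethylphenyl enters. The position is therefore not indifferent to the aryl exchange, yet the separation is incomplete, as a 1.7-fold higher number from compound 3 to compound 4 (0.24 log units; within the scatter) leaves compound 4 unresolved from the 4-aminophenyl member. No supporting measurement bears on the origin of these steps.

The change from 3-methylphenyl to 2,4-dimethylphenyl alters the methyl pattern as a whole, so the compounds shown do not assign the step to either methyl group; 2-methylphenyl and 4-methylphenyl at the same place would separate the two. As far as these compounds go, how a carboxylic acid or a longer alkyl chain on the aryl ring would read out also remains open.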